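A few compounds are considered here, and "the series" means these few. Any claim that something is new, unique, unknown or untested is made for them only; others in the source may bear on it.

Measured so far in a functional assay on HT-29 cells (Homo sapiens) for inhibition, read by sulforhodamine B assay, with a stated time of 48 h; on this read-out lower numbers stand for stronger inhibition and higher numbers for weaker inhibition:
- compound 1 `CCNC(=O)Nc1ccc(/C=C/c2cccc(Cl)c2)cc1`: > 20000 nM
- compound 2 `CCNC(=O)Nc1ccc(/C=C\c2cccc(Cl)c2)cc1`: 26000 nM
- compound 3 `Cc1cc(C)cc(/C=C/c2ccc(N3CCNC3=O)cc2)c1`: 14000 nM

Compound 1 gives only a limit, > 20000 nM, and not a number.

The next compound to be read is compound 4 `O=C1NCCN1c1ccc(/C=C/c2cccc(Cl)c2)cc1`, with 2-oxoimidazolidin-1-yl in place of (ethylcarbamoyl)amino on an aromatic carbon, para to a group of 9 heavy atoms: 2-oxoimidazolidin-1-yl in place of (ethylcarbamoyl)amino on an aromatic carbon.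

Going by the values given here, only one measured step starts from compound 1, and it gives little guidance. This is a step that the limit leaves unreadable from compound 1 to compound 2, and its size cannot be read. It also concerns a different change, (the fact that compounds 1 and 2 differ only in the configuration as drawn), so it does not measure the replacement at issue here.

Among the compounds with values here, the nearest guide is compound 3, the one measured compound that carries 2-oxoimidazolidin-1-yl, at 14000 nM. Compound 2 gives 26000 nM, within the scatter of that value.

On these values, compound 4 is expected to stay in the same weak range in this assay. The expected step is an at least 1.2-fold lower number from compound 1 to compound 4 (0.09 log units; that floor lies within the scatter), small and towards stronger inhibition if it can be read at all, and it may not exceed the scatter.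

For compound 4 the estimate is 16000 nM, with an expected range from 7000 nM to 40000 nM.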

Compound 4, half-maximal inhibitory concentration: 17000 nM
Estimate against measurement, compound 4: 1.1-fold (0.03 log units) below, within the range that was stated.
By their numbers in this assay, from the lowest: compounds 3, 4 and 2 (each within the scatter of the next).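

The replacement of (ethylcarbamoyl)amino by 2-oxoimidazolidin-1-yl, on an aromatic carbon para to a group of 9 heavy atoms, can now be followed on a single shared core in this assay, and it gives an at least 1.1-fold lower number from compound 1 to compound 4 (0.07 log units; that floor lies within the scatter). The change closes the open chain into a five-membered non-aromatic ring and takes the hydrogen-bond donors from 2 to 1 with the heavy-atom count unchanged, yet the values stay in the weak range, and no gain beyond the scatter is established. Only a floor can be given for this step, and its true size stays open: the limit of > 20000 nM in this assay, at which 1 of the 4 values shown sits.

The step between the two double-bond configurations cannot be read, so the effect of that configuration on this read-out remains unsettled, and compound 4 has no counterpart with the opposite configuration among the compounds shown. Also open, as far as these compounds go, is how this position would respond on the same core to a primary amine, a carboxylic acid, a six-membered ring or a chain longer than ethyl.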